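A few compounds are considered here, and "the series" means these few. Any claim that something is new, unique, unknown or untested is made for them only; others in the source may bear on it.

Compound 1 `Cc1cc(OCc2nnc(SCc3cccc(F)c3)o2)cc2oc(=O)cc(C)c12`: 26000 nM
Compound 2 `Cc1cc(OCc2nnc(SCc3ccc(Cl)cc3Cl)o2)cc2oc(=O)cc(C)c12`: < 5000 nM
Compound 3 `CCS(=O)(=O)c1nnc(COc2cc(C)c3c(C)cc(=O)oc3c2)o1`: > 100000 nM

All three values come from a functional assay on MCF7 cells (Homo sapiens) for antiproliferative activity, read by MTT assay, with a stated time of 24 h; on this read-out higher numbers stand for weaker inhibition and lower numbers for stronger inhibition. For compound 2 the value is a limit of this assay rather than a number. For compound 3 the value is also a limit, and compound 3 stands at the weak end of the three. Compound 4 `CCCCCCS(=O)(=O)c1nnc(COc2cc(C)c3c(C)cc(=O)oc3c2)o1` has not yet been measured; it differs from compound 3 by butyl in place of hydrogen on a saturated chain carbon, two bonds along the chain from a sulfonyl sulfur. Going by the values given here, no measured step alters this chain. The steps that touch the sulfonyl, an at least 3.8-fold higher number from compound 1 to compound 3 (0.58 log units; beyond the scatter) and an at least 20-fold higher number from compound 2 to compound 3 (1.30 log units; beyond the scatter), both moved toward weaker inhibition and left compound 3 at the limit of > 100000 nM in this assay, at which 1 of the 3 values shown sits. The step of a number no higher from compound 3 to compound 4 (the limit leaves the size open) is therefore expected to be none beyond the scatter. Compound 4 is expected near 100000 nM, between 30000 nM and 300000 nM.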

Compound 4, half-maximal inhibitory concentration: > 100000 nM
Compound 4 was reported as a limit; the forecaster's own chance of this, stated with the estimate: 60%; the middle value lies on the limit itself.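

In this assay compound 4 gives > 100000 nM, which is a limit of the assay. Adding butyl to the ethyl chain of compound 3 leaves no readable step, because both compounds sit at the same limit: the limit of > 100000 nM in this assay, at which 2 of the 4 values shown sit. The longer hexyl chain still does not restore the activity of the benzylsulfanyl compounds, with an at least 20-fold higher number from compound 2 to compound 4 (1.30 log units; beyond the scatter) and an at least 3.8-fold higher number from compound 1 to compound 4 (0.58 log units; beyond the scatter).

On these data alone, how far compound 3 and compound 4 truly differ stays open. So does whether a 2,4-dichlorobenzylsulfonyl group, or a chain ending in an amine, would bring activity back into the readable range.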